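The compounds below may be only part of what the source reports. "The series", "measured", "known", "first", "only" and "open" are said of these compounds alone.

Measured so far in an ADME assay on the whole organism (Rattus norvegicus), at a dose of 2 mg/kg by the oral route; on this read-out higher numbers stand for higher exposure at the dose given and lower numbers for lower exposure:
- Compound 1 `COc1cc(OCc2cccc(-c3ccc(C(F)(F)F)cn3)c2)c2cc(-c3cn4nc(OC)sc4n3)oc2c1` gives 459 ng.h/mL
- Compound 2 `COc1cc(OCc2cccc(-c3ccc(OC)nc3)c2)c2cc(-c3cn4nc(OC)sc4n3)oc2c1` gives 1800 ng.h/mL
- Compound 3 `COc1cc(OCc2cccc(OCc3ccccc3)c2)c2cc(-c3cn4nc(OC)sc4n3)oc2c1` gives 339 ng.h/mL

Compound 3 cannot be told apart from compound 1, since the measured change, a 1.4-fold lower number from compound 1 to compound 3 (0.13 log units; within the scatter), stays within the usual scatter. It stands clearly under compound 2, with a 5.3-fold lower number from compound 2 to compound 3 (0.73 log units; beyond the scatter).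

Compound 4 `COc1ccc(-c2cccc(COc3cc(OC)cc4oc(-c5cn6nc(OC)sc6n5)cc34)c2)nc1` has not yet been measured in this assay. Its structure puts 5-methoxypyridin-2-yl in place of benzyloxy on an aromatic carbon.

All three measured steps bear on this change, and they do not agree. Benzyloxy replaced the pyridine-bearing group of compound 2 with a clear loss, but replaced that of compound 1 with no change beyond the scatter. The choice of pyridine group also mattered, giving a 3.9-fold higher number from compound 1 to compound 2 (0.59 log units; beyond the scatter). The new group in compound 4 has the pyridin-2-yl attachment seen in compound 1 and a methoxy group as in compound 2, so a result between those two compounds seems the fairest guess.

A modest rise is therefore expected, namely a 2.4-fold higher number from compound 3 to compound 4 (0.37 log units; beyond the scatter), though no change beyond the scatter remains possible. The estimated value for compound 4 is 800 ng.h/mL, with an expected range from 300 ng.h/mL to 2200 ng.h/mL.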

Compound 4, area under the concentration-time curve: 1700 ng.h/mL
Estimate against measurement, compound 4: 2.1-fold (0.33 log units) below; low and high end bracket the measured number.
By their numbers in this assay, from the lowest: compounds 3 and 1 (each within the scatter of the next); then compounds 4 and 2 (each within the scatter of the next).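

In this assay, a pyridin-2-yl attachment proves compatible with high numbers: with methoxy in place of trifluoromethyl on that ring, the change is clear (a 3.7-fold higher number from compound 1 to compound 4 (0.57 log units; beyond the scatter)). Moving the attachment and the methoxy group around the pyridine, as the two methoxypyridine compounds do, leaves no difference that can be read (a 1.1-fold lower number from compound 2 to compound 4 (0.02 log units; within the scatter)). Benzyloxy now falls short of a second methoxypyridine group (a 5.0-fold higher number from compound 3 to compound 4 (0.70 log units; beyond the scatter)), so among these four compounds the two carrying a methoxypyridine group form the high pair, while the trifluoromethyl and benzyloxy compounds form the low pair. Nothing shown here gives a reason for these differences.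

Whether the methoxy group itself is what matters stays open, since the compounds shown include no pyridine without a substituent and none with an ethoxy group, a hydroxyl group or an amine on that ring. From the compounds shown here alone, whether a methoxy group on a plain benzene ring at this position would give the same high numbers also remains unknown, as the pyridine nitrogen and the methoxy group always arrive together in these compounds.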